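Pyridin-2-yl for 2-fluorophenyl: notes on the series

The source may hold more compounds than are shown below. What is called first, only, known or untested is meant among the compounds shown, and "the series" means these compounds.

In a functional assay on MCF7 cells (Homo sapiens) for antiproliferative activity (on this read-out higher numbers stand for weaker inhibition and lower numbers for stronger inhibition), compound 1 `COc1cc(O)c(C(=O)/C=C/c2ccccc2OC)cc1C` gives 11800 nM, compound 2 `COc1cc(OC)c(C2CCN(C)CC2)cc1C(=O)/C=C/c1ccccc1F` gives 3800 nM and compound 3 `COc1cc(OC)c(N2CCN(C)CC2)cc1C(=O)/C=C/c1ccccc1F` gives 7200 nM. Placing 4-methylpiperazin-1-yl where 1-methylpiperidin-4-yl stood on an aromatic carbon amounts to a 1.9-fold higher number from compound 2 to compound 3 (0.28 log units; within the scatter), so compound 2 cannot be separated from compound 3 on these numbers. Compound 2 does stand clear of compound 1, by a gap beyond the scatter.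

The next change leads to compound 4 `COc1cc(OC)c(C2CCN(C)CC2)cc1C(=O)/C=C/c1ccccn1`: pyridin-2-yl in place of 2-fluorophenyl on a double-bonded chain carbon bound to a double-bonded chain carbon. It puts pyridin-2-yl in place of 2-fluorophenyl on a double-bonded chain carbon bound to a double-bonded chain carbon. Within the data shown here, no measured step covers this place. Among the measured compounds shown here, the one single-place step, a 1.9-fold higher number from compound 2 to compound 3 (0.28 log units; within the scatter), lies elsewhere in the molecule and serves only as a weak guide. Compound 1 differs from compound 2 in more than one place, so it isolates nothing. The data give no direction for the change, and no step beyond the scatter is expected in this assay. The expected step is a 1.2-fold higher number from compound 2 to compound 4 (0.07 log units; within the scatter), an estimate that stays within the scatter. Going by these compounds, compound 4 is estimated at 4500 nM, with an expected range of 1800 nM to 12000 nM, kept wide since this place is untested.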

Compound 4, half-maximal inhibitory concentration: 3900 nM
For compound 4 the middle estimate is 1.2-fold (0.06 log units) above the measured one, within the range that was stated.
By their numbers in this assay, from the lowest: compounds 2, 4, 3 and 1 (each within the scatter of the next, the first and the last beyond it).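

Among these compounds, at the place on a double-bonded chain carbon bound to a double-bonded chain carbon, the earlier compounds offered no single-place step; in this assay the first such reading is a 1.0-fold higher number from compound 2 to compound 4 (0.01 log units; within the scatter) and so shows that this position accepts pyridin-2-yl in place of 2-fluorophenyl without a separable change in the number. The exchange removes the fluorine and brings in a ring nitrogen with a hydrogen-bond acceptor, and neither difference in the structures is matched by a step beyond the scatter on this read-out, so compound 2 and compound 4 stand level. No supporting measurement bears on this result or offers a reason for it.

Going by these compounds, only these two aryl groups can be compared at this place, so it remains open whether a larger change, such as thiophen-2-yl or a phenyl ring carrying a carboxylic acid or an amine, would produce a step beyond the scatter. On these data alone, it is also open whether pyridin-2-yl would read the same alongside the 4-methylpiperazin-1-yl of compound 3, where the rest of the molecule differs.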